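Cyano on the pendant phenyl of compound 1

This account rests on a few compounds, and the source may have more. Where it says the series, first, only, none or still open, it means among the compounds named here.

Compound 1 `CC(=O)Nc1cccc(C2CCN(CCCn3c(-c4ccccc4)nc4ccccc43)CC2)c1` is the reference point of this pair. For the measured compounds named here, in an assay for displacement of a labelled ligand from melanin-concentrating hormone receptor 1 (Homo sapiens), read by fluorescence (a higher number here means a weaker inhibitor, a lower number a stronger inhibitor), compound 1 gives 2 nM, the lowest of the two numbers measured so far. Going by the values given here, its only measured neighbour is compound 2 `CC(=O)Nc1cccc(C2CCN(CCCn3c(-c4cccc(C(F)(F)F)c4)nc4ccccc43)CC2)c1`, which carries trifluoromethyl in place of hydrogen on an aromatic carbon of the pendant phenyl; in this assay compound 2 gives 30 nM, and the step of a 15-fold higher number from compound 1 to compound 2 (1.18 log units; beyond the scatter) is the single piece of evidence on substitution of that ring.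

Compound 3 `CC(=O)Nc1cccc(C2CCN(CCCn3c(-c4ccc(C#N)cc4)nc4ccccc43)CC2)c1` differs from compound 1 by cyano in place of hydrogen on an aromatic carbon. The change sits on the same ring as the change to compound 2 but brings a different group at a different place, so the earlier step is only a loose guide. Among the compounds with values here, that step was large and ran toward weaker binding; with no contrary example, the expectation is that compound 3 also moves in that direction, though by less, as the estimated step of a 5.0-fold higher number from compound 1 to compound 3 (0.70 log units; beyond the scatter) indicates. For compound 3 the expected number in this assay is 10 nM, with a range of 3 nM to 40 nM.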

Compound 3, half-maximal inhibitory concentration: 16 nM
Estimate against measurement, compound 3: 1.6-fold (0.20 log units) below, and the stated range covers the measured number.
By their numbers in this assay, from the lowest: compound 1; then compounds 3 and 2 (each within the scatter of the next).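

Para to a large group on the pendant phenyl, cyano also moves the number away from that of compound 1 in this assay (an 8.0-fold higher number from compound 1 to compound 3 (0.90 log units; beyond the scatter)), so the loss on this ring is no longer tied to trifluoromethyl alone. The two substituted rings cannot be told apart in this assay, since 4-cyanophenyl and 3-(trifluoromethyl)phenyl lie within the scatter of each other (a 1.9-fold lower number from compound 2 to compound 3 (0.27 log units; within the scatter)), while both stand clearly apart from the plain phenyl of compound 1. Nothing available speaks to the origin of this loss.

On these data alone, compounds 2 and 3 differ in both the group and its place on the ring, so it remains open whether the loss follows the group, the place, or simply the presence of any substituent on this phenyl. Also open, as far as these compounds go, is whether a smaller group such as fluorine or methyl, or an amine or a carboxylic acid, on this ring would hold the level of compound 1 at 2 nM or fall away from it as cyano and trifluoromethyl do.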